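Difluoromethyl-fluorophenyl variant of an oxadiazole IDO1 series

A few compounds are considered here, and "the series" means these few. Any claim that something is new, unique, unknown or untested is made for them only; others in the source may bear on it.

Measured so far:
compound 1 `NS(=O)(=O)CC(=O)NCCSc1nonc1/C(=N/O)Nc1cccc(Cl)c1` gives 10 nM
compound 2 `C[C@H](CSc1nonc1/C(=N/O)Nc1ccc(F)c(Br)c1)NC(=O)CS(N)(=O)=O` gives 12 nM
compound 3 `CS(=O)(=O)NCCSc1nonc1/C(=N/O)Nc1ccc(F)c(Br)c1` gives 9.3 nM

All three values come from an assay for inhibition of Indoleamine 2,3-dioxygenase 1 (Homo sapiens), read by fluorescence, with a stated time of 24 h; on this read-out lower numbers stand for stronger inhibition and higher numbers for weaker inhibition. Compound 1 holds the second highest of the three numbers; its nearest neighbour is compound 3 and its furthest is compound 2, and both of those gaps lie within the scatter, so the three compounds cannot be ranked against one another on these data.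

The next compound, compound 4 `NS(=O)(=O)CC(=O)NCCSc1nonc1/C(=N/O)Nc1ccc(F)c(C(F)F)c1`, differs from compound 1 in one place: 3-(difluoromethyl)-4-fluorophenyl in place of 3-chlorophenyl on an amine nitrogen. For the measured compounds named here, no measured pair in the set isolates this change, so the size of the step rests on the spread of the numbers seen so far, which is narrow across two different aryl groups and three different side chains.

Expectation: the step from compound 1 to compound 4 in this assay is estimated as a 1.2-fold higher number from compound 1 to compound 4 (0.08 log units; within the scatter), that is, no movement beyond the scatter in either direction. Compound 4 is therefore expected to give about 12 nM, with a plausible range from 5 nM to 30 nM.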

Compound 4, half-maximal inhibitory concentration: 13 nM
The estimate for compound 4 lay 1.1-fold (0.03 log units) below the measured number; low and high end bracket the measured number.
By their numbers in this assay, from the lowest: compounds 3, 1, 2 and 4 (each within the scatter of the next).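

In this assay the replacement of 3-chlorophenyl by 3-(difluoromethyl)-4-fluorophenyl on the amine nitrogen gives a 1.3-fold higher number from compound 1 to compound 4 (0.11 log units; within the scatter) and stays within the scatter. For the compounds shown here, this is the first comparison that isolates a single place: with the side chain of compound 1 held fixed, this position accepts the larger aryl group, with fluorine in place of chlorine, without a step beyond the scatter. No measurement on hand bears on why the two aryl groups read alike.

All the aryl groups shown are phenyl rings carrying halogen, so the effect of an amine or a carboxylic acid on that ring remains open. Also open, on these data alone, is whether the same replacement stays within the scatter on a different side chain, such as a longer chain.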